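Ethyl in Place of Trifluoromethylphenyl: Another Limit Expected

The compounds below may be only part of what the source reports. "The series", "measured", "known", "first", "only" and "open" are said of these compounds alone.

Compound 3 `CN(C[C@H]1Cc2c(cccc2N2CCN(c3cccc(C(F)(F)F)c3)CC2)CN1)[C@H]1CCCc2cccnc21` has no measured number in a functional assay on CCRF-CEM cells for agonist activity at C-X-C chemokine receptor type 4 (Homo sapiens), read by calcium flux, with a stated time of 25 min; a lower number here means that less compound is needed, a higher number that more compound is needed for the effect. In this assay compound 3 gives > 30000 nM, which is a limit of the assay. Compound 1 `CN(C[C@H]1Cc2c(cccc2N2CCN(C3CC3)CC2)CN1)[C@H]1CCCc2cccnc21` likewise reaches only a limit, giving > 30000 nM in this assay. Compound 2 `CC(C)N1CCN(c2cccc3c2C[C@H](CN(C)[C@H]2CCCc4cccnc42)NC3)CC1` also gives > 30000 nM, again a limit. Because all three values sit at the limit of > 30000 nM in this assay, at which 3 of the 3 values shown sit, the steps a step that the two limits leave unreadable from compound 1 to compound 2, a step that the two limits leave unreadable from compound 1 to compound 3 and a step that the two limits leave unreadable from compound 2 to compound 3 cannot be sized. Compound 4 `CCN1CCN(c2cccc3c2C[C@H](CN(C)[C@H]2CCCc4cccnc42)NC3)CC1` differs from compound 3 by ethyl in place of 3-(trifluoromethyl)phenyl on an amine nitrogen in a ring. Among the measured compounds shown here, because the limit of > 30000 nM in this assay, at which 3 of the 3 values shown sit, holds every value measured so far, compound 4 is expected to remain at the limit, with the step that the limit leaves unreadable from compound 3 to compound 4 expected to be unreadable. Compound 4 is therefore estimated at 40000 nM, between 10000 nM and 150000 nM.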

Compound 4, half-maximal effective concentration: > 30000 nM
Compound 4: no number, only a limit; the forecaster's own chance of this, stated with the estimate: 85%; the middle value is on the limit's open side.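

In this assay compound 4 gives > 30000 nM, which is a limit and not a number. Its steps from compound 1, compound 2 and compound 3 cannot be read. How far apart these four compounds truly lie stays open: the limit of > 30000 nM in this assay, at which 4 of the 4 values shown sit.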